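Chloro on a Second Core: Isatin Analogues in Breast Cancer Cells

This account rests on a few compounds, and the source may have more. Where it says the series, first, only, none or still open, it means among the compounds named here.

Compound 1 `Cc1ccc2nc(/N=C3\C(=O)N(CN(C)C)c4ccccc43)sc2c1`: 35500 nM
Compound 2 `Cc1ccc2nc(/N=C3\C(=O)N(CN(C)C)c4cccc(Cl)c43)sc2c1`: 28100 nM
Compound 3 `CN(C)CN1C(=O)C(=O)c2ccccc21`: 50200 nM

In a functional assay on MDA-MB-468 cells (Homo sapiens) for cytotoxicity, read by sulforhodamine B assay, with a stated time of 48 h (a lower number here means a stronger inhibitor of growth, a higher number a weaker inhibitor of growth), compound 1 gives 35500 nM and compound 2 gives 28100 nM. The change between them, (chloro in place of hydrogen on an aromatic carbon), made a step of a 1.3-fold lower number from compound 1 to compound 2 (0.10 log units; within the scatter). Compound 3 `CN(C)CN1C(=O)C(=O)c2ccccc21` is a smaller molecule; the difference between its core and the core of compound 1 is not broken down here. In this assay compound 3 gives 50200 nM, close to the other two.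

Compound 4 `CN(C)CN1C(=O)C(=O)c2c(Cl)cccc21` carries the same change on the core of compound 3, (chloro in place of hydrogen on an aromatic carbon). Because the step of a 1.3-fold lower number from compound 1 to compound 2 (0.10 log units; within the scatter) fell within the scatter, the step from compound 3 to compound 4 is expected to be likewise small, a 1.3-fold lower number from compound 3 to compound 4 (0.10 log units; within the scatter). Compound 4 is therefore estimated at 40000 nM in this assay, with a range from 18000 nM to 90000 nM.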

Compound 4, concentration for 50% growth inhibition: 107000 nM
Compound 4: the middle estimate sits 2.7-fold (0.43 log units) below what was measured; measured number above the stated range.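

On the core of compound 3, chloro in place of hydrogen on an aromatic carbon did not behave as it had on the core of compound 1. In this assay the new step is a 2.1-fold higher number from compound 3 to compound 4 (0.33 log units; beyond the scatter). Set beside the earlier step, the two do not agree: the same change on two cores in this assay, a 1.3-fold lower number (0.10 log units; within the scatter) from compound 1 to compound 2 and a 2.1-fold higher number (0.33 log units; beyond the scatter) from compound 3 to compound 4, 2.7-fold (0.43 log units) apart, beyond the scatter of two such steps. This shows that the step did not carry from one core to the other here, but two pairs do not show why, or how the change would behave on a further core.

The compounds shown leave open whether fluoro, bromo or methoxy at the same place would give the same gap between the cores. They also leave open whether morpholine in place of the dimethylamino group would alter the step on either core.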